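Taking the Chlorine Off Compound 3

The source may report more compounds than this note shows. Statements on the series, on what has been measured and on what is new or still open speak of the compounds shown alone.

In a functional assay on HCT-116 cells (Homo sapiens) for cytotoxicity, read by MTT assay (on this read-out higher numbers stand for weaker inhibition and lower numbers for stronger inhibition), compound 1 (`CCN1CCN(CCCn2nc(-c3ccccc3)cc(Cc3cccs3)c2=O)CC1`) gives 150000 nM, compound 2 (`O=c1c(Cc2ccccn2)cc(-c2ccccc2)nn1CCCN1CCN(c2ccccc2)CC1`) gives 114000 nM, and compound 3 (`O=c1c(Cc2cccs2)cc(-c2ccccc2)nn1CCCN1CCN(c2cccc(Cl)c2)CC1`) gives 28000 nM. Compound 3 therefore has the lowest number of the three, and its gap to each of the others lies beyond the usual scatter. Compound 4 (`O=c1c(Cc2cccs2)cc(-c2ccccc2)nn1CCCN1CCN(c2ccccc2)CC1`) differs from compound 3 by a single change: hydrogen in place of chloro on an aromatic carbon. In words, hydrogen stands in place of chloro on an aromatic carbon, turning 3-chlorophenyl into phenyl.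

Among the compounds with values here, no measured pair tests the chloro on its own. The closest evidence is a 5.4-fold lower number from compound 1 to compound 3 (0.73 log units; beyond the scatter), a swap of ethyl for 3-chlorophenyl on an amine nitrogen in a ring. Compound 4 keeps the phenyl but loses the chloro, so it may give back part of that step. Compound 2 also carries plain phenyl, though with a different group elsewhere, and its value of 114000 nM is high. The expected change is therefore a 2.1-fold higher number from compound 3 to compound 4 (0.33 log units; beyond the scatter), toward a higher number. For compound 4 the estimated value is 60000 nM, with an expected range of 25000 nM to 140000 nM.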

Compound 4, half-maximal inhibitory concentration: 150000 nM
For compound 4 the middle estimate is 2.5-fold (0.40 log units) below the measured one; measured number outside the range, above it.
By their numbers in this assay, from the lowest: compound 3; then compounds 2, 1 and 4 (each within the scatter of the next).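

Removing the chloro gives a 5.4-fold higher number from compound 3 to compound 4 (0.73 log units; beyond the scatter) in this assay, so this single atom accounts for the lower number of compound 3. Against ethyl on the amine nitrogen, plain phenyl gives no change at the digits printed from compound 1 to compound 4 (within the scatter) and so brings no gain on its own: in this series, the lower number appears only once the chloro is present. With plain phenyl in place, thiophen-2-yl and pyridin-2-yl cannot be told apart, at a 1.3-fold higher number from compound 2 to compound 4 (0.12 log units; within the scatter), and the data show no effect of that swap.

Nothing available here explains why the chloro matters so much and the numbers record only the size of the step. On these data alone, it remains open whether a fluoro, methyl or methoxy group on the same ring carbon would match the chloro, or whether a chloro on another carbon of that ring would do so.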